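Swapping bromine for chlorine on a benzyl sulfide

A few compounds are considered here, and "the series" means these few. Any claim that something is new, unique, unknown or untested is made for them only; others in the source may bear on it.

Of the compounds shown here, two have been measured so far. Compound 1 `O=C(O)c1ccc(C(=O)/C(=C\c2ccc(F)c([N+](=O)[O-])c2)SCc2ccc(Cl)cc2)cc1` and compound 2 `CN(C)c1ccc(/C=C(/SCc2ccc(Br)cc2)C(=O)c2ccc(C(=O)O)cc2)cc1` share a core built around a carbonyl and a benzoic acid, and both carry a halogen on a benzyl group attached through sulfur. In a functional assay on DU-145 cells (Homo sapiens) for inhibition, read by trypan blue exclusion, with a stated time of 96 h (a higher number here means a weaker inhibitor of growth, a lower number a stronger inhibitor of growth), compound 1 gives 50000 nM and compound 2 gives 50000 nM. Compound 2 thus stands level with compound 1, the two values lying within the scatter of each other.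

Compound 3 `CN(C)c1ccc(/C=C(/SCc2ccc(Cl)cc2)C(=O)c2ccc(C(=O)O)cc2)cc1` has not yet been measured. It differs from compound 2 in one place only: chloro in place of bromo on an aromatic carbon. Because compound 2 gives 50000 nM and compound 1 a matching value, no basis exists here for expecting a shift beyond the scatter. The step from compound 2 to compound 3 is expected to be about no change at the digits printed from compound 2 to compound 3 (within the scatter). For compound 3 the estimate in this assay is 50000 nM, with a likely range from 25000 nM to 100000 nM.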

Compound 3, concentration for 50% growth inhibition: 1000 nM
Compound 3: middle estimate off by 50-fold (1.70 log units), on the high side; measured number outside the range, below it.
By their numbers in this assay, from the lowest: compound 3; then compounds 1 and 2 (each within the scatter of the next).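

In this assay chloro in place of bromo gives a 50-fold lower number from compound 2 to compound 3 (1.70 log units; beyond the scatter) with nothing else changed, so a single halogen swap on this aromatic carbon can move the number well beyond the scatter. The chloro group is not enough on its own: 4-(dimethylamino)phenyl in place of 4-fluoro-3-nitrophenyl gives a 50-fold lower number from compound 1 to compound 3 (1.70 log units; beyond the scatter) while the 4-chlorobenzyl group stays the same. Among these three compounds, the low number appears only where 4-chlorobenzyl and 4-(dimethylamino)phenyl occur together, and nothing measured here explains this.

Still open, from the compounds shown here alone, is whether a fluoro group, a methyl group or plain hydrogen at this aromatic carbon would keep the low number. Going by these compounds, it is also open whether the low number survives with an amide or an ester in place of the carboxylic acid.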